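Pyridyl to cyclopropyl at the thiophene carbon: expected half-life

The source may report more compounds than this note shows. Statements on the series, on what has been measured and on what is new or still open speak of the compounds shown alone.

Working notes on the series, read out in an ADME assay on microsomes from liver (Homo sapiens) for metabolic stability; on this read-out higher numbers stand for a longer-lived compound and lower numbers for a shorter-lived compound.

Compound 1 `CC#C[C@@H](Cc1nnn[nH]1)c1ccc(OCc2ccc3scc(-c4cncnc4C)c3c2)cc1` gives 0.233 h in this assay. Compound 2 `CC#C[C@@H](Cc1nnn[nH]1)c1ccc(OCc2ccc3scc(-c4cc(OCCOC)ccc4C)c3c2)cc1` gives 0.867 h in this assay, and a 3.7-fold higher number from compound 1 to compound 2 (0.57 log units; beyond the scatter). Compound 3 `CC#C[C@@H](Cc1nnn[nH]1)c1ccc(OCc2ccc3scc(-c4cccnc4C)c3c2)cc1` returns only a limit of this assay, < 0.0667 h, and so stands at the short-lived edge of the three values shown, sitting at the limit of < 0.0667 h in this assay, at which 1 of the 3 values shown sits. Both steps into compound 3 lie beyond the scatter: an at least 3.4-fold lower number from compound 1 to compound 3 (0.54 log units; beyond the scatter), and an at least 12-fold lower number from compound 2 to compound 3 (1.11 log units; beyond the scatter).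

Compound 4 `CC#C[C@@H](Cc1nnn[nH]1)c1ccc(OCc2ccc3scc(C4CC4)c3c2)cc1` has not yet been measured. The change from compound 3 is cyclopropyl in place of 2-methylpyridin-3-yl on an aromatic carbon. The measured steps that bear on it are the two that alter the same aromatic carbon, leading into compound 3, and both were downward and at least modest to large. Among the compounds with values here, no measured step involves cyclopropyl, so the direction for compound 4 rests only on compound 3 sitting at a limit, from which a number can only be equal or higher. The step is expected to be an at least 2.9-fold higher number from compound 3 to compound 4 (0.47 log units; beyond the scatter), upward, modest in size, though an unchanged limit cannot be excluded. Compound 4 is estimated at 0.2 h in this assay, within 0.06 h to 0.7 h.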

Compound 4, half-life: 0.267 h
For compound 4 the middle estimate is 1.3-fold (0.13 log units) below the measured one, within the range that was stated.
By their numbers in this assay, from the lowest: compounds 1 and 4 (each within the scatter of the next); then compound 2. At a limit, below all of these: compound 3.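

Within the data shown here, at the aromatic carbon two ring bonds from the ring sulfur, cyclopropyl is the first group that is a three-membered non-aromatic ring rather than a six-membered aromatic ring, and in this assay it gives an at least 4.0-fold higher number from compound 3 to compound 4 (0.60 log units; beyond the scatter). A six-membered aromatic ring at this carbon is therefore not needed to match compound 1, as cyclopropyl in place of 4-methylpyrimidin-5-yl gives a 1.1-fold higher number from compound 1 to compound 4 (0.06 log units; within the scatter), whereas the swap from 5-(2-methoxyethoxy)-2-methylphenyl gives a 3.2-fold lower number from compound 2 to compound 4 (0.51 log units; beyond the scatter). The value of compound 3 is a limit and not a number: the limit of < 0.0667 h in this assay, at which 1 of the 4 values shown sits.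

On these data alone, it remains open whether the higher number with 5-(2-methoxyethoxy)-2-methylphenyl belongs to the 2-methoxyethoxy chain or to the phenyl ring that carries it. Also open, as far as these compounds go, is how a larger saturated ring such as cyclohexyl, or a cyclopropyl carrying an amine, would read at this carbon in this assay.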